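Swapping chloro for bromo on the cyclopropylphenyl group

This account rests on a few compounds, and the source may have more. Where it says the series, first, only, none or still open, it means among the compounds named here.

Within the data shown here, compound 2 `CNC(=O)[C@@]12C[C@@H]1[C@@H](n1cnc3c(NC4CC4c4cccc(Cl)c4)nc(C#Cc4ccccc4)nc31)[C@H](O)[C@@H]2O` gives 11.2 nM in an assay on CHO cells for displacement of a labelled ligand from adenosine receptor A3 (Homo sapiens), read by scintillation counting, with a stated time of 60 min (on this read-out lower numbers stand for stronger inhibition and higher numbers for weaker inhibition), the higher of the two numbers so far; its nearest neighbour, compound 1 `CNC(=O)[C@@]12C[C@@H]1[C@@H](n1cnc3c(NC4CC4c4ccccc4)nc(C#Cc4ccccc4)nc31)[C@H](O)[C@@H]2O`, gives 6.16 nM in this assay. Among the measured compounds shown here, the one comparable step, a 1.8-fold higher number from compound 1 to compound 2 (0.26 log units; within the scatter), arose from adding a chloro group. Compound 3 `CNC(=O)[C@@]12C[C@@H]1[C@@H](n1cnc3c(NC4CC4c4cccc(Br)c4)nc(C#Cc4ccccc4)nc31)[C@H](O)[C@@H]2O` differs from compound 2 by bromo in place of chloro on an aromatic carbon. Exchanging one halogen for the next is a smaller change than adding a halogen, so from compound 2 to compound 3 a step of a 1.1-fold higher number from compound 2 to compound 3 (0.03 log units; within the scatter) is expected, no larger than the scatter. Compound 3 is therefore estimated at 12 nM, within 5 nM to 30 nM.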

Compound 3, inhibition constant: 14.5 nM
The estimate for compound 3 lay 1.2-fold (0.08 log units) below the measured number; measured number inside the range.
By their numbers in this assay, from the lowest: compounds 1, 2 and 3 (each within the scatter of the next, the first and the last beyond it).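

In this assay, bromo in place of chloro at this position gives a 1.3-fold higher number from compound 2 to compound 3 (0.11 log units; within the scatter) and so leaves the two halogens indistinguishable. Bromo in place of hydrogen gives a 2.4-fold higher number from compound 1 to compound 3 (0.37 log units; beyond the scatter) and is the first step here to pass the scatter, though only modestly. No measurement at hand explains this shift.

Still open, going by these compounds, is whether a fluoro group, a methoxy group or an amine at the same place would give a similar number. Also open, on these data alone, is whether a bromo group on another carbon of the phenyl ring would behave alike.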